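The compounds below may be only part of what the source reports. "The series", "measured", "known", "first", "only" and "open" are said of these compounds alone.

Measured so far in a functional assay on NUGC-3 cells (Homo sapiens) for cytotoxicity, read by sulforhodamine B assay, with a stated time of 72 h; a lower number here means a stronger inhibitor of growth, a higher number a weaker inhibitor of growth:
compound 1 `O=C(Nc1cc(C(F)(F)F)cc(C(F)(F)F)c1)C1CCc2ccccc2N1C(=O)c1ccccc1Cl` gives 1930 nM.
compound 2 `CC(=O)N1c2ccccc2CCC1C(=O)Nc1cc(C(F)(F)F)cc(C(F)(F)F)c1` gives > 70000 nM.
compound 3 `CC(=O)N1c2ccccc2CCC1C(=O)Nc1ccccc1C(F)(F)F` gives > 80000 nM.

The value of compound 3 is a limit of this assay and not a number, (the limit of > 80000 nM in this assay, at which 1 of the 3 values shown sits). The value of compound 2 is likewise a limit and not a number, (the limit of > 70000 nM in this assay, at which 1 of the 3 values shown sits).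

Compound 1 and compound 2 share a core and differ in one place only: 2-chlorophenyl in place of methyl on a carbonyl carbon. In this assay that change gives an at least 36-fold lower number from compound 2 to compound 1 (1.55 log units; beyond the scatter), a step that starts from a limit and so is itself only a lower bound on the true gain.

Compound 3 stands on a different anilide; the difference between the core of compound 2 and the core of compound 3 is not broken down here.

Compound 4 `O=C(Nc1ccccc1C(F)(F)F)C1CCc2ccccc2N1C(=O)c1ccccc1Cl` is not yet measured. It stands to compound 3 as compound 1 stands to compound 2: 2-chlorophenyl in place of methyl on a carbonyl carbon. The place is described in the same words for both pairs, so this is the same change made a second time among these compounds.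

Among the measured compounds shown here, for compound 4 in this assay the step is expected to be of a similar order to the earlier one, an at least 5.3-fold lower number from compound 3 to compound 4 (0.72 log units; beyond the scatter), resting on the single measured instance of the change, an at least 36-fold lower number from compound 2 to compound 1 (1.55 log units; beyond the scatter), with the caution that compound 3 gives only a limit and the new starting anilide has no measured partner. The estimate for compound 4 is 15000 nM, expected between 3000 nM and 80000 nM, with a real chance that the assay again reports only a limit.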

Compound 4, concentration for 50% growth inhibition: 2730 nM
The estimate for compound 4 lay 5.5-fold (0.74 log units) above the measured number; the whole stated range lies above it.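

In this assay, putting 2-chlorophenyl in place of methyl on the carbonyl carbon gives a large gain on the second anilide as well, an at least 29-fold lower number from compound 3 to compound 4 (1.46 log units; beyond the scatter), so the change carries over to both cores shown, and in each case it takes a compound that reads only as a limit to one with a measured value. Both steps start from a limit of the assay and not from a number, so each is only a lower bound on the true gain, and their sizes cannot be set against each other: the same change on two cores in this assay, an at least 36-fold lower number (1.55 log units; beyond the scatter) from compound 2 to compound 1 and an at least 29-fold lower number (1.46 log units; beyond the scatter) from compound 3 to compound 4; the limit leaves it open whether they differ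

Two cores are a narrow base, and these results show neither how large the gain really is on either core nor that it would hold on an anilide outside this small set.

The compounds shown leave open how much of the gain needs the chlorine, since unsubstituted phenyl does not appear among them, and whether a longer alkyl chain or a chain carrying an amine on the same carbonyl carbon would do as well. They also leave open how the change behaves on an anilide carrying a nitrile or a carboxylic acid in place of trifluoromethyl.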